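The compounds below may be only part of what the source reports. "The series", "measured", "known", "first", "only" and "open" are said of these compounds alone.

Compound 1 `Cc1ccc(NC(=O)CSc2snnc2-c2ccc(Br)cc2Br)c([N+](=O)[O-])c1` — in an ADME assay on MT4 cells (Homo sapiens) for cytotoxicity, read by MTT assay, with a stated time of 5 days (a higher number here means that more compound is tolerated, a lower number that less compound is tolerated), compound 1 gives > 229000 nM, which is a limit of the assay rather than a number. Compound 2 `O=C(CSc1snnc1-c1ccc(Br)cc1Br)Nc1ccccc1Cl` — compound 2 gives > 240000 nM, again a limit. Compound 3 `O=C(CSc1snnc1-c1ccc(Br)cc1Br)Nc1nccs1` — compound 3 gives 87800 nM.

Compound 3 therefore stands as the only one of the three with an actual number; the other two sit at limits. Among the compounds with values here, the one step that can be read among the measured compounds is an at least 2.7-fold lower number from compound 2 to compound 3 (0.43 log units; beyond the scatter), which took compound 2 from its limit down to the number seen for compound 3.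

Compound 4 `Cc1ccc(NC(=O)CSc2snnc2-c2ccc(Br)cc2Br)cc1` is not yet measured. It differs from compound 3 in one place: 4-methylphenyl in place of 1,3-thiazol-2-yl on an amide-type nitrogen. This change runs in the opposite sense to the measured step: a six-membered aromatic ring of carbon only returns to the amide-type nitrogen, as in compound 1 and compound 2, both of which gave only limits (the limit of > 229000 nM in this assay, at which 1 of the 3 values shown sits, (the limit of > 240000 nM in this assay, at which 1 of the 3 values shown sits)). The account therefore expects a step upward in this assay for compound 4, of about the size seen in reverse in the measured step, and quite possibly a return to a limit. The estimate for compound 4 is 230000 nM, with a range from 90000 nM to 600000 nM. The step this expectation means is a 2.6-fold higher number from compound 3 to compound 4 (0.42 log units; beyond the scatter).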

Compound 4, half-maximal cytotoxic concentration: 24000 nM
Beside the measured number, compound 4's estimate is 9.6-fold (0.98 log units) above it, and the stated range ends above it.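

In this assay, the new result shows that a six-membered aromatic ring of carbon only on the amide-type nitrogen does not in itself bring a return to high tolerated concentrations: the change to 4-methylphenyl gives a 3.7-fold lower number from compound 3 to compound 4 (0.56 log units; beyond the scatter), so compound 4 lies lower than the 1,3-thiazol-2-yl compound. The groups carried by that ring therefore matter as much as the kind of ring, which compounds 1 and 2 alone could not show, since 4-methylphenyl in place of 2-chlorophenyl gives an at least 10-fold lower number from compound 2 to compound 4 (1.00 log units; beyond the scatter), and hydrogen in place of nitro on an aromatic carbon gives an at least 9.5-fold lower number from compound 1 to compound 4 (0.97 log units; beyond the scatter). Nothing measured here accounts for these steps.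

Going by these compounds, what remains open is how much of the drop belongs to the methyl group of 4-methylphenyl, a question that a plain phenyl on the amide-type nitrogen would help to settle. On these data alone, it is also open whether a carboxylic acid or an amine in place of that methyl would move the tolerated concentration up or down.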